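Ethoxycarbonyl to Acetyl on a Shared Core

The compounds below may be only part of what the source reports. "The series", "measured", "known", "first", "only" and "open" are said of these compounds alone.

Compound 1 `CCN(CC)c1ccc2cc(C(=O)c3ccc(N4CCN(C(=O)COc5ccc(Cl)cc5Cl)CC4)cc3)oc2c1`: 6170 nM
Compound 2 `CCOC(=O)N1CCN(c2ccc(C(=O)c3cc4ccc(N(CC)CC)cc4o3)cc2)CC1`: > 40000 nM
Compound 3 `CCN(CC)c1ccc2cc(C(=O)c3ccc(N4CCN(S(=O)(=O)c5ccc(C(F)(F)F)cc5)CC4)cc3)oc2c1`: 170 nM

In a functional assay on SGC-7901 cells (Homo sapiens) for cytotoxicity, read by MTT assay, with a stated time of 48 h (a lower number here means a stronger inhibitor, a higher number a weaker inhibitor), compound 2 gives only a limit, > 40000 nM, so its true number is not known. Compound 3 gives 170 nM and compound 1 gives 6170 nM, both real numbers. Compound 4 `CCN(CC)c1ccc2cc(C(=O)c3ccc(N4CCN(C(C)=O)CC4)cc3)oc2c1` carries the change (methyl in place of ethoxy on a carbonyl carbon), turning the ethoxycarbonyl group into acetyl. Within the data shown here, the only measured step at this carbonyl carbon is an at least 6.4-fold higher number from compound 1 to compound 2 (0.81 log units; beyond the scatter), where a (2,4-dichlorophenoxy)methyl group was replaced by ethoxy and the reading reached the limit (the limit of > 40000 nM in this assay, at which 1 of the 3 values shown sits). Compound 4 keeps an even smaller group there, so no step beyond the scatter is expected. Compound 4 is therefore estimated at 40000 nM, with a range of 15000 nM to 100000 nM. That estimate corresponds to an expected step of a number no higher from compound 2 to compound 4 (the limit leaves the size open).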

Compound 4, half-maximal inhibitory concentration: 25600 nM
Compound 4: middle estimate off by 1.6-fold (0.19 log units), on the high side, and the stated range covers the measured number.
By their numbers in this assay, from the lowest: compound 3; then compound 1; then compound 4. At a limit, above all of these: compound 2.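

Compound 2 stands at a limit, not a number: the limit of > 40000 nM in this assay, at which 1 of the 4 values shown sits.

Compound 4 gives this carbonyl carbon its first real reading with a small group, yet the step is only an at least 1.5-fold lower number from compound 2 to compound 4 (0.19 log units; that floor lies within the scatter), so methyl and ethoxy cannot be ranked here. The chain matters more: the step is a 4.1-fold higher number from compound 1 to compound 4 (0.62 log units; beyond the scatter), with hydrogen replacing 2,4-dichlorophenoxy.

From the compounds shown here alone, it remains open how a longer chain such as propyl, or an amine on this carbonyl carbon, would read, and whether any simple group there could approach the number of compound 3 170 nM.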